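The source may hold more compounds than are shown below. What is called first, only, known or untested is meant among the compounds shown, and "the series" means these compounds.

The measured compounds:
compound 1, `COc1ccc(-c2cn(C/C=C3\OC(=O)C(OCc4ccccc4)=C3OCc3ccccc3)nn2)cc1`, in a functional assay on HepG2 cells (Homo sapiens) for antiproliferative activity, read by MTT assay, with a stated time of 72 h; a lower number here means a stronger inhibitor, a higher number a weaker inhibitor: > 100000 nM, a limit of the assay rather than a number
compound 2, `CC(C)(C)c1cn(C[C@H](O)[C@H]2OC(=O)C(OCc3ccccc3)=C2OCc2ccccc2)nn1`, in this assay : 29200 nM

Compound 1 sits at the limit of > 100000 nM in this assay, at which 1 of the 2 values shown sits. For the measured compounds named here, compound 2 therefore carries the only number in this assay, and since the other reading is a limit, no measured step between two numbers exists to set a scale for what a change at the five-membered aromatic ring with 3 nitrogen does to the half-maximal inhibitory concentration.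

Compound 3, `O=C1O[C@H]([C@@H](O)Cn2cc(CCO)nn2)C(OCc2ccccc2)=C1OCc1ccccc1`, differs from compound 2 in one place: 2-hydroxyethyl in place of tert-butyl on an aromatic carbon. The group that leaves has no hydrogen-bond donor or acceptor; the 2-hydroxyethyl that enters brings one of each. Without a measured step to lean on, the step from compound 2 to compound 3 is expected to be modest, more likely toward weaker inhibition than stronger, and the expected step of a 1.5-fold higher number from compound 2 to compound 3 (0.19 log units; within the scatter) reaches only a little beyond the usual scatter. Compound 3 is accordingly estimated at 45000 nM, within a range from 15000 nM to 150000 nM, with a real chance that this assay reports only a limit for it.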

Compound 3, half-maximal inhibitory concentration: 68100 nM
Beside the measured number, compound 3's estimate is 1.5-fold (0.18 log units) below it, within the range that was stated.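

In this assay, the aromatic carbon of the five-membered ring with 3 nitrogen now has its first measured step, a 2.3-fold higher number from compound 2 to compound 3 (0.37 log units; beyond the scatter), so this change at this position carries a modest cost that lies beyond the usual scatter. The cost is limited, since compound 3, with the 2-hydroxyethyl and its hydrogen-bond donor and acceptor in place of the tert-butyl, still gives a number in this assay rather than a limit. The data shown offer no measured property that would explain this single step.

For the compounds shown here, compound 1 gives > 100000 nM, a limit and not a number, and it yields no step that can be read. With one pair to go on, the compounds shown cannot separate the loss of tert-butyl from the arrival of the hydroxyl, and they leave open how a 2-methoxyethyl, a 2-aminoethyl, a carboxylic acid or a longer chain such as 3-hydroxypropyl would read at this position.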